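This account rests on a few compounds, and the source may have more. Where it says the series, first, only, none or still open, it means among the compounds named here.

Measured so far:
- compound 1 `CSc1ccc(Cc2nn(C(C)(C)C)c(=O)c3ccccc23)cc1`: > 100000 nM in a functional assay on aorta with Alpha-1D adrenergic receptor (Rattus norvegicus) as the target; on this read-out lower numbers stand for an effect already at smaller amounts and higher numbers for an effect only at larger amounts of compound
- compound 2 `COc1ccc(Cc2nn(C(C)(C)C)c(=O)c3ccccc23)cc1OC`: 10000 nM in this assay
- compound 3 `CCCCn1nc(Cc2ccc(SC)cc2)c2ccccc2c1=O`: > 100000 nM in this assay

The value of compound 1 is a limit of this assay and not a number. The value of compound 3 is likewise a limit and not a number. Going by the values given here, compound 2 gives the only number in the set, 10000 nM.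

From compound 1 to compound 3 the change is butyl in place of tert-butyl on an aromatic nitrogen. Its size is a step that the two limits leave unreadable from compound 1 to compound 3, which cannot be read because of the limit of > 100000 nM in this assay, at which 2 of the 3 values shown sit.

Compound 4 `CCCCn1nc(Cc2ccc(OC)c(OC)c2)c2ccccc2c1=O` is not yet measured. From compound 2 to compound 4 the change is butyl in place of tert-butyl on an aromatic nitrogen. The place differs from the earlier pair only in what sits around it: in compound 1 the nitrogen is meta to a group of 9 heavy atoms, in compound 2 it is meta to a large group. So the two changes are the same kind of change, not the same. How the core of compound 2 differs from the core of compound 1 is not broken down here.

Among the compounds with values here, nothing measured tells the size of this step, as the one observed instance sits between two limits. The expectation for compound 4 therefore rests on the value of compound 2, 10000 nM, with a wide band around it; the step from compound 2 to compound 4 is estimated as a 1.5-fold higher number from compound 2 to compound 4 (0.18 log units; within the scatter). Compound 4 is estimated at 15000 nM, between 4000 nM and 60000 nM, in this assay.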

Compound 4, half-maximal effective concentration: 5400 nM
The estimate for compound 4 lay 2.8-fold (0.44 log units) above the measured number, and the stated range covers the measured number.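

In this assay, butyl in place of tert-butyl on an aromatic nitrogen gives a 1.9-fold lower number from compound 2 to compound 4 (0.27 log units; within the scatter), so on the core of compound 2 the two chains cannot be told apart on this read-out. On these data alone, the same change on the core of compound 1 cannot be read, as compound 1 and compound 3 both stand at a limit of the assay and not at a number: the limit of > 100000 nM in this assay, at which 2 of the 4 values shown sit. The series therefore holds one readable instance of this change, which shows that swapping these two chains is tolerated on the core of compound 2 but does not show that this result carries over to another core, and whether the core of compound 1 would behave alike stays unknown.

The compounds shown leave open how the read-out responds to other groups on the aromatic nitrogen, such as a longer chain like hexyl, or a chain ending in an amine or a carboxylic acid. They also leave open whether any change to the group on the shared core gives a step that is readable and lies beyond the usual scatter of this kind of measurement.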